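The compounds below may be only part of what the source reports. "The series", "measured", "known", "first", "only" and "open" are said of these compounds alone.

In a functional assay on A-375 cells (Homo sapiens) for cytotoxicity, read by MTT assay, with a stated time of 72 h (on this read-out higher numbers stand for weaker inhibition and lower numbers for stronger inhibition), the three measured compounds give:

Compound 1 `N/C(=N\NC(=S)N1CCCCCC1)c1ccccn1` gives 740 nM.
Compound 2 `Cc1cccc(/C(N)=N/NC(=S)N2CCCCCC2)n1` gives 1800 nM.
Compound 3 `Cc1cccc(/C(N)=N/NC(=S)N2CCCC2)n1` gives 2900 nM.

Compound 1 and compound 2 share a core and differ in one place: hydrogen in place of methyl on an aromatic carbon. In this assay this change gave a 2.4-fold lower number from compound 2 to compound 1 (0.39 log units; beyond the scatter). The cores of compound 2 and compound 3 differ in a way that is not broken down here; their two values lie within the usual scatter of each other.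

Compound 4 `N/C(=N\NC(=S)N1CCCC1)c1ccccn1` is not yet measured. It differs from compound 3 in one place: hydrogen in place of methyl on an aromatic carbon. This is the same change as that from compound 2 to compound 1, at the same place on the ring. Because that step gave a 2.4-fold lower number from compound 2 to compound 1 (0.39 log units; beyond the scatter), a step of similar size is expected from compound 3 to compound 4, namely a 2.4-fold lower number from compound 3 to compound 4 (0.38 log units; beyond the scatter). Compound 4 is therefore estimated at 1200 nM, expected to fall between 600 nM and 2500 nM.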

Compound 4, half-maximal inhibitory concentration: 600 nM
The estimate for compound 4 lay 2.0-fold (0.30 log units) above the measured number; low and high end bracket the measured number.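

Replacing the methyl with hydrogen again lowered the number in this assay on the second core (a 4.8-fold lower number from compound 3 to compound 4 (0.68 log units; beyond the scatter)). The two steps point the same way, and their sizes do not differ by more than the scatter allows: the same change on two cores in this assay, a 2.4-fold lower number (0.39 log units; beyond the scatter) from compound 2 to compound 1 and a 4.8-fold lower number (0.68 log units; beyond the scatter) from compound 3 to compound 4, 2.0-fold (0.30 log units) apart, within the scatter of two such steps. On these two cores, then, the change carried over in direction and, within that scatter, in size, but two pairs in one cell assay cannot show that it would carry over to other cores in this series, nor explain why it lowers the number.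

The compounds shown leave open what other groups at this place on the ring would do, such as an ethyl group, a chlorine atom or an amine.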